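From indanyl to a chlorinated four-membered ring

The source may report more compounds than this note shows. Statements on the series, on what has been measured and on what is new or still open speak of the compounds shown alone.

Compound 2 `c1ccc2c(c1)CCC2CCCN1CCN(c2cccc3c2OCCO3)CC1` gives 204 nM in an assay on isolated protein for binding affinity to 5-hydroxytryptamine receptor 1B (Rattus norvegicus) (on this read-out higher numbers stand for weaker inhibition and lower numbers for stronger inhibition), and sits among the two low numbers of the three shown; compound 3 `C1=C(CCN2CCN(c3cccc4c3OCCO4)CC2)c2ccccc2CC1` gives 229 nM, within the scatter of compound 2, while compound 1 `c1ccc2c(c1)CC2CCCN1CCN(c2cccc3c2OCCO3)CC1` gives 646 nM, beyond the scatter. Compound 4 `Clc1cccc2c1CC2CCCN1CCN(c2cccc3c2OCCO3)CC1` has not been measured; it carries a group of 9 heavy atoms (8 carbon, 1 chlorine; one four-membered non-aromatic ring of carbon only, one six-membered aromatic ring of carbon only) in place of a group of 9 heavy atoms (9 carbon; one five-membered non-aromatic ring of carbon only, one six-membered aromatic ring of carbon only), on a saturated chain carbon, three bonds along the chain from an amine nitrogen in a ring. Going by the values given here, the only measured step that bears on this is a 3.2-fold lower number from compound 1 to compound 2 (0.50 log units; beyond the scatter), which went from the four-membered ring to the five-membered ring. Among the compounds with values here, compound 4 returns to the four-membered ring and adds a chlorine, for which no measured step exists. A modest upward step is therefore expected, estimated as a 2.5-fold higher number from compound 2 to compound 4 (0.39 log units; beyond the scatter). Compound 4 is expected to give about 500 nM in this assay, with a range from 200 nM to 1500 nM.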

Compound 4, inhibition constant: 1100 nM
Beside the measured number, compound 4's estimate is 2.2-fold (0.34 log units) below it, within the range that was stated.
By their numbers in this assay, from the lowest: compounds 2 and 3 (each within the scatter of the next); then compounds 1 and 4 (each within the scatter of the next).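

Chloro in place of hydrogen gives a 1.7-fold higher number from compound 1 to compound 4 (0.23 log units; within the scatter) in this assay and so does not set compound 4 apart from compound 1 on this read-out. The exchange at the saturated chain carbon gives a 5.4-fold higher number from compound 2 to compound 4 (0.73 log units; beyond the scatter) and leaves the chlorinated four-membered-ring group clearly behind the 2,3-dihydro-1H-inden-1-yl group of compound 2. Nothing available explains either step. On these data alone, whether fluoro or methoxy in place of the chlorine would behave alike remains open. So does the size of the step from chloro on the 2,3-dihydro-1H-inden-1-yl group.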